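Methylamino for Cyclopropylmethoxy: Expected Shift in Maximal Response

The compounds below may be only part of what the source reports. "The series", "measured", "known", "first", "only" and "open" are said of these compounds alone.

Compound 1 `COc1ccccc1-c1ccn(CCC(C)C)c(=O)c1C#N`: 120%
Compound 2 `CC(C)CCn1ccc(-c2ccc(OCC3CC3)cc2)c(C#N)c1=O`: 192%
Compound 3 `CC(C)CCn1ccc(-c2ccc(OCC3CC3)c(Cl)c2)c(C#N)c1=O`: 206%

In a functional assay on CHO cells for positive allosteric modulation of metabotropic glutamate receptor 2 (Homo sapiens), read by scintillation counting and GTPgammaS binding, with a stated time of 30 min (on this read-out higher numbers stand for larger maximal responses and lower numbers for smaller maximal responses), compound 2 gives 192%, the second highest of the three numbers shown. The closest value is that of compound 3, which gives 206% in this assay. The step between them is a number 14 percentage points higher from compound 2 to compound 3 (beyond the scatter). Compound 1 gives 120% in this assay, far below compound 2.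

Compound 4 `CNc1ccc(-c2ccn(CCC(C)C)c(=O)c2C#N)cc1` has not yet been measured. It differs from compound 2 by methylamino in place of cyclopropylmethoxy on an aromatic carbon. Among the compounds with values here, no measured step makes this kind of change: the only one-place step, a number 14 percentage points higher from compound 2 to compound 3 (beyond the scatter), concerns a chloro substituent and keeps the cyclopropylmethoxy group. Without direct precedent, a downward step is expected for compound 4, a number 42 percentage points lower from compound 2 to compound 4 (beyond the scatter), with wide uncertainty. Compound 4 is therefore estimated at 150%, within a range from 100% to 200%.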

Compound 4, largest response reached (Emax), in percent of the reference or control that the assay uses: 186%
For compound 4 the middle estimate is 36 percentage points below the measured one, within the range that was stated.
By their numbers in this assay, from the lowest: compound 1; then compounds 4 and 2 (each within the scatter of the next); then compound 3.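

Replacing cyclopropylmethoxy with methylamino on this aromatic carbon, para to a large group, gives a number 6 percentage points lower from compound 2 to compound 4 (within the scatter) in this assay. For this pair, the three-membered ring and the oxygen of the leaving group are therefore not needed for a response of this size, and a group with fewer heavy atoms and a hydrogen-bond donor is tolerated here. The compounds shown leave open whether dimethylamino or ethylamino at this place would hold the response, and whether a chloro substituent would shift the response of compound 4 as it did for compound 2. No measurement shown accounts for this result.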